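The source may hold more compounds than are shown below. What is called first, only, known or untested is meant among the compounds shown, and "the series" means these compounds.

Compound 1 `COc1ccc(Br)cc1C(=O)Nc1ccccc1`: > 100000 nM
Compound 2 `O=C(Nc1ccc(Sc2nc3ccccc3s2)cc1)c1ccccc1`: > 100000 nM

In an ADME assay on HEK293 cells (Homo sapiens) for cytotoxicity, read by reporter gene assay and resazurin assay, with a stated time of 48 h (on this read-out higher numbers stand for lower toxicity in this test and lower numbers for higher toxicity in this test), compound 1 gives > 100000 nM, which is a limit of the assay and not a number. Compound 2 likewise gives > 100000 nM, again a limit. The two measured compounds therefore share one reading: the limit of > 100000 nM in this assay, at which 2 of the 2 values shown sit. Compound 2 thus has no exact value from which to measure a change.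

Compound 3 `O=C(Nc1ccc(Sc2nc3ccccc3s2)cc1)c1cc(Br)ccc1O` carries 5-bromo-2-hydroxyphenyl in place of phenyl on a carbonyl carbon. For the measured compounds named here, no pair of measured compounds shows a step in this assay, so the expectation rests on this structural change alone. A moderate step towards lower numbers, beyond the usual scatter, is expected, though compound 3 may also stay at the limit. The estimated change is an at least 2.0-fold lower number from compound 2 to compound 3 (0.30 log units; that floor lies within the scatter). For compound 3 the expected value is 50000 nM, with an estimated range of 10000 nM to 100000 nM.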

Compound 3, half-maximal cytotoxic concentration: 42000 nM
Compound 3: the middle estimate sits 1.2-fold (0.08 log units) above what was measured; low and high end bracket the measured number.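

Setting 5-bromo-2-hydroxyphenyl in place of phenyl on a carbonyl carbon gives, in this assay, an at least 2.3-fold lower number from compound 2 to compound 3 (0.37 log units; beyond the scatter), so this position can move the reading beyond the scatter, and compound 3 is the first compound shown with an exact value. Going by these compounds, compound 2 gives > 100000 nM, which is a limit and not a number, so the step is only a floor and its full size stays unknown. The other compounds offer no exact reading for comparison: the limit of > 100000 nM in this assay, at which 2 of the 3 values shown sit.

Bromine and the hydroxy group enter together, so the compounds shown leave open which of them goes with the step. Also open, on these data alone, is whether chlorine in place of the bromine, or an amine in place of the hydroxy group, would read the same way in this assay.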